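Swapping the Aryl Ketone for a Pyridine Ring

The source may hold more compounds than are shown below. What is called first, only, known or untested is meant among the compounds shown, and "the series" means these compounds.

Compound 1, `COc1ccc(-c2cc3ccccc3nc2/C=C/C(=O)c2c(OC)cccc2OC)cc1`: 3830 nM in a functional assay on SK-BR-3 cells (Homo sapiens) for antiproliferative activity, read by XTT assay, with a stated time of 72 h; a lower number here means a stronger inhibitor, a higher number a weaker inhibitor
Compound 2, `COc1ccc(-c2cc3ccccc3nc2/C=C/C(=O)c2ccc(N)cc2)cc1`: 8560 nM in this assay
Compound 3, `COc1ccc(-c2cc3ccccc3nc2/C=C/C(=O)c2ccc([N+](=O)[O-])cc2)cc1`: 590 nM in this assay

These three compounds share one core and differ only in the aryl group attached to the carbonyl carbon. Compound 3 gives the lowest number of the three: a 6.5-fold lower number from compound 1 to compound 3 (0.81 log units; beyond the scatter) and a 15-fold lower number from compound 2 to compound 3 (1.16 log units; beyond the scatter), both beyond the scatter, so compound 3 stands as the strongest inhibitor among them.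

Compound 4 `COc1ccc(-c2cc3ccccc3nc2/C=C/C(=O)c2ccccn2)cc1` keeps the shared core and alters the same position: pyridin-2-yl in place of 4-nitrophenyl on a carbonyl carbon. Among the measured compounds shown here, no measured step tests a pyridin-2-yl group, so the expectation rests on how much the group on the carbonyl carbon has mattered so far. Those steps were modest to large: a 2.2-fold higher number from compound 1 to compound 2 (0.35 log units; beyond the scatter), a 6.5-fold lower number from compound 1 to compound 3 (0.81 log units; beyond the scatter) and a 15-fold lower number from compound 2 to compound 3 (1.16 log units; beyond the scatter). Only the 4-nitrophenyl group gave a low number; both other groups sat higher. Compound 4 is therefore expected to give a higher number than compound 3, a step of a 4.2-fold higher number from compound 3 to compound 4 (0.63 log units; beyond the scatter), placing it closer to compound 1. The estimate for compound 4 is 2500 nM, with a range from 700 nM to 9000 nM.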

Compound 4, half-maximal inhibitory concentration: 370 nM
Beside the measured number, compound 4's estimate is 6.8-fold (0.83 log units) above it; measured number outside the range, below it.
By their numbers in this assay, from the lowest: compounds 4 and 3 (each within the scatter of the next); then compound 1; then compound 2.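

The low number at this position turns out not to belong to the 4-nitrophenyl group alone: with a 1.6-fold lower number from compound 3 to compound 4 (0.20 log units; within the scatter), pyridin-2-yl and 4-nitrophenyl cannot be told apart in this assay, even though the pyridin-2-yl group has no nitro group and fewer heavy atoms. The ring that enters also carries its nitrogen within the aromatic ring rather than on a substituent, and it stands far from the two other aryl groups, with a 23-fold lower number from compound 2 to compound 4 (1.36 log units; beyond the scatter) against 4-aminophenyl and a 10-fold lower number from compound 1 to compound 4 (1.01 log units; beyond the scatter) against 2,6-dimethoxyphenyl. No measurement available here explains what the pyridin-2-yl and 4-nitrophenyl groups have in common that sets them apart from those two groups.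

The compounds shown leave open how much the ring nitrogen of pyridin-2-yl matters, and whether it matters where it sits, which a plain phenyl group, a pyridin-3-yl group and a pyridin-4-yl group on the carbonyl carbon would each help to settle. They also leave open whether a nitrile in place of the nitro group on the phenyl ring would keep the number as low as that of compound 3.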